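A Hydroxyphenyl for a Chlorophenyl on a Shared Core

A few compounds are considered here, and "the series" means these few. Any claim that something is new, unique, unknown or untested is made for them only; others in the source may bear on it.

Of the compounds shown here, two of a shared core have been measured in a physicochemical assay for lipophilicity, measured as octanol-water partition; on this read-out higher numbers stand for higher lipophilicity and lower numbers for lower lipophilicity. Compound 1 `CC1=C(C(=O)OCc2ccccn2)C(c2ccc(Cl)cc2)C2=C(CCCC2=O)N1` gives 2.24 in this assay. Compound 2 `CC1=C(C(=O)OCc2cccnc2)C(c2ccc(Br)cc2)C2=C(CCCC2=O)N1`, which carries a different ester and a bromine in place of chlorine, gives 2.05. Among the compounds with values here, these two numbers lie within the usual scatter of each other, so no order can be read from them, and no single-point step between measured compounds is available.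

Compound 3 `CC1=C(C(=O)OCc2ccccn2)C(c2cccc(O)c2)C2=C(CCCC2=O)N1` has not been measured. It differs from compound 1 in one place: 3-hydroxyphenyl in place of 4-chlorophenyl on a saturated ring carbon. Nothing in the measured pair speaks to this kind of change, so the expectation rests on the change itself.

The step from compound 1 to compound 3 is expected to be a number 1.24 log units lower from compound 1 to compound 3 (beyond the scatter), a downward move beyond the scatter. Compound 3 is therefore estimated at 1, with a likely range from 0.5 to 1.5.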

Compound 3, partition coefficient: 1.58
Beside the measured number, compound 3's estimate is 0.58 log units below it; the measured number lies above the stated range.
By their numbers in this assay, from the lowest: compound 3; then compounds 2 and 1 (each within the scatter of the next).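

Within the data shown here, with 3-hydroxyphenyl in place of 4-chlorophenyl on the saturated ring carbon, this assay gives a number 0.66 log units lower from compound 1 to compound 3 (beyond the scatter), the first step on the shared core that differs in one place. The earlier pair could show no order, whereas this result shows that the read-out responds to a change of group at this position. Both groups have 7 heavy atoms, but only the entering one has 1 hydrogen-bond donor and 1 hydrogen-bond acceptor, and no measurement here gives a reason for the step.

The step swaps chlorine for hydroxyl and also changes the number in the group's name from 4 to 3, and the compounds shown do not separate these two differences. Going by these compounds, how far the number would move with plain phenyl, 4-hydroxyphenyl or 3-aminophenyl at this position remains open.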